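Extending the hydroxyalkyl chain on the shared core

The source may report more compounds than this note shows. Statements on the series, on what has been measured and on what is new or still open speak of the compounds shown alone.

Measured so far:
Compound 1 `OCCCNCc1nc2c(OCC3CCCCC3)cccc2[nH]1`: 28500 nM
Compound 2 `OCCCCNCc1nc2c(OCC3CCCCC3)cccc2[nH]1`: 30000 nM

In an assay on cells for inhibition of interleukin-5 receptor subunit alpha (Mus musculus), read by WST assay, with a stated time of 48 h, in the presence of a further agent that is not named here (a higher number here means a weaker inhibitor, a lower number a stronger inhibitor), compound 2 gives the highest of the two numbers, though its nearest neighbour, compound 1, differs by a step within the scatter. Compound 3 `OCCCCCNCc1nc2c(OCC3CCCCC3)cccc2[nH]1` carries hydroxymethyl in place of hydroxy on a saturated chain carbon, four bonds along the chain from an amine nitrogen. Among the measured compounds shown here, the one step that bears on this, a 1.1-fold higher number from compound 1 to compound 2 (0.02 log units; within the scatter), was the same kind of chain lengthening and stayed within the scatter. Compound 3 is therefore expected to show no step beyond the scatter, a 1.0-fold higher number from compound 2 to compound 3 (0.01 log units; within the scatter). For compound 3 the estimate in this assay is 31000 nM, with a range from 15000 nM to 65000 nM.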

Compound 3, half-maximal inhibitory concentration: > 30000 nM
Compound 3 ended at the assay's limit (the forecaster's own chance of this, stated with the estimate: 12%); the middle value lies beyond the limit too.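

In this assay compound 3 gives > 30000 nM as a limit of the assay, not a number: the limit of > 30000 nM in this assay, at which 1 of the 3 values shown sits.
One new step (a number no lower from compound 2 to compound 3 (the limit leaves the size open)) cannot be read for size, and the other new step (an at least 1.0-fold higher number from compound 1 to compound 3 (0.02 log units; that floor lies within the scatter)) sets only a floor that lies within the scatter. On these data alone, this further lengthening of the hydroxyalkyl chain therefore brought no lower number, though how far the true value of compound 3 lies beyond the limit stays unknown.

Still open, as far as these compounds go, is whether an amine or a carboxylic acid in place of the hydroxy would give a lower number on this chain.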